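Working notes on a 3-chlorobenzyl to 2-fluorobenzyl change

The source may report more compounds than this note shows. Statements on the series, on what has been measured and on what is new or still open speak of the compounds shown alone.

Measured compounds:
- compound 1, `O=C1/C(=C/c2ccccc2F)CN(Cc2cn(Cc3ccccc3F)nn2)C/C1=C\c1ccccc1F`, in a functional assay on MDA-MB-231 cells (Homo sapiens) for cytotoxicity, read by MTT assay, with a stated time of 24 h; a lower number here means a stronger inhibitor, a higher number a weaker inhibitor: 16000 nM
- compound 2, `O=C1/C(=C/c2ccccc2F)CN(Cc2cn(Cc3cccc(Cl)c3)nn2)C/C1=C\c1ccccc1F`, in this assay: 12000 nM
- compound 3, `Cc1ccc(/C=C2\CN(Cc3cn(Cc4cccc(Cl)c4)nn3)C/C(=C\c3ccc(C)cc3)C2=O)cc1`, in this assay: 9000 nM

Compound 2 and compound 1 share one core and differ only at the group on the saturated chain carbon bound to an aromatic nitrogen: 2-fluorophenyl in place of 3-chlorophenyl on a saturated chain carbon bound to an aromatic nitrogen. This change gives a 1.3-fold higher number from compound 2 to compound 1 (0.12 log units; within the scatter), so the two values of compound 2 and compound 1 in this assay cannot be told apart.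

Compound 3 carries a different core; how the core of compound 3 differs from that of compound 2 is not broken down here. Its value in this assay sits close to that of compound 2 and of compound 1, all three within the usual scatter of one another.

Compound 4, `Cc1ccc(/C=C2\CN(Cc3cn(Cc4ccccc4F)nn3)C/C(=C\c3ccc(C)cc3)C2=O)cc1`, is not yet measured. It differs from compound 3 by 2-fluorophenyl in place of 3-chlorophenyl on a saturated chain carbon bound to an aromatic nitrogen. This is the same change as that from compound 2 to compound 1, at the same place, now made on the core of compound 3. Going by the values given here, the only evidence on this change is the single pair of compound 2 and compound 1, whose step is a 1.3-fold higher number from compound 2 to compound 1 (0.12 log units; within the scatter); whether it behaves alike on the core of compound 3 is unknown.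

The step from compound 3 to compound 4 in this assay is expected to be a 1.2-fold higher number from compound 3 to compound 4 (0.09 log units; within the scatter), resting on the step of a 1.3-fold higher number from compound 2 to compound 1 (0.12 log units; within the scatter).

Compound 4 is therefore estimated at 11000 nM in this assay, with a likely range of 5500 nM to 22000 nM.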

Compound 4, half-maximal inhibitory concentration: 10000 nM
Compound 4: the middle estimate sits 1.1-fold (0.04 log units) above what was measured; low and high end bracket the measured number.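

In this assay, 2-fluorophenyl in place of 3-chlorophenyl on a saturated chain carbon bound to an aromatic nitrogen gives a 1.1-fold higher number from compound 3 to compound 4 (0.05 log units; within the scatter), so the two groups cannot be told apart on the core of compound 3, just as on the core of compound 2. Set side by side, the two steps do not differ: the same change on two cores in this assay, a 1.3-fold higher number (0.12 log units; within the scatter) from compound 2 to compound 1 and a 1.1-fold higher number (0.05 log units; within the scatter) from compound 3 to compound 4, 1.2-fold (0.08 log units) apart, within the scatter of two such steps. This shows that the change leaves no readable step on either of these two cores, but because neither step rises above the scatter, the agreement is between two null results and does not show that a real effect of this change carries from one core to another, nor does it say anything about cores beyond these two.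

Only two groups at this place and two cores are shown, which leaves the reach of this position in the series largely unmapped. On these data alone, it remains open whether an unsubstituted benzyl, a chain carrying an amine, a carboxylic acid or a longer chain at this place would give a step beyond the scatter, and whether such a step would then hold on both cores.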